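Working notes: polar group exchange on the shared core

The compounds below may be only part of what the source reports. "The series", "measured", "known", "first", "only" and "open" are said of these compounds alone.

Compound 1 `COc1ccc2ccc(Cc3ccccc3)c(O)c2c1` gives 3500 nM in an assay on RBL-1 cells with Polyunsaturated fatty acid 5-lipoxygenase (Rattus norvegicus) as the target; a higher number here means a weaker inhibitor, a lower number a stronger inhibitor.
Compound 2 `Cc1ccc(C)c2c(O)c(Cc3ccccc3)ccc12` gives 120 nM in this assay.
Compound 3 `OCCOc1c(Cc2ccccc2)ccc2ccccc12` gives 40000 nM in this assay.

Compound 3 shows the highest number of the three in this assay; compound 1 is nearest and compound 2 furthest, and both gaps lie beyond the scatter. Compound 4 `Nc1c(Cc2ccccc2)ccc2ccccc12` is not yet measured; it differs from compound 3 by amino in place of 2-hydroxyethoxy on an aromatic carbon. Among the measured compounds shown here, no two measured compounds differ in one place, so the size of this step rests on the three values alone. Since compound 1 and compound 2 give lower numbers than compound 3 in this assay, a downward move beyond the scatter is expected for compound 4. Compound 4 is expected at 3000 nM, range 500 nM to 20000 nM. The expected step is a 13-fold lower number from compound 3 to compound 4 (1.12 log units; beyond the scatter).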

Compound 4, half-maximal inhibitory concentration: 9100 nM
Estimate against measurement, compound 4: 3.0-fold (0.48 log units) below; low and high end bracket the measured number.
By their numbers in this assay, from the lowest: compound 2; then compound 1; then compound 4; then compound 3.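

Amino in place of 2-hydroxyethoxy on this aromatic carbon, ortho to a benzyl group, gives a 4.4-fold lower number from compound 3 to compound 4 (0.64 log units; beyond the scatter) in this assay, the first one-place step in the series. The number at this position therefore moves with the group it carries, and the smaller group gives the lower number, though this single step cannot separate loss of the chain from gain of the amino. No measurement shown accounts for the step.

The compounds shown leave open how a methoxy group, an acetamido group or a carboxylic acid on this carbon would read on the core of compound 3. As far as these compounds go, a longer hydroxyalkoxy chain there is equally open.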